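A few compounds are considered here, and "the series" means these few. Any claim that something is new, unique, unknown or untested is made for them only; others in the source may bear on it.

Series notes. Compound 1 `CN(C)CCCn1cc[n+](C)c1/C=N/O` sits at a limit in a physicochemical assay for lipophilicity (on this read-out lower numbers stand for lower lipophilicity and higher numbers for higher lipophilicity), < -3. Compound 2 `CN(CCCn1cc[n+](C)c1/C=N/O)S(C)(=O)=O` gives -2.63 in this assay, and compound 3 `C[n+]1ccn(CCCNS(=O)(=O)C(F)(F)F)c1/C=N/O` gives -1.26; compound 3 stands highest of the two numbers, the nearest being compound 2. Among the compounds with values here, the one measured step, a number at least 0.37 log units higher from compound 1 to compound 2 (beyond the scatter), concerns a different change and starts from the limit (the limit of < -3 in this assay, at which 1 of the 3 values shown sits). Compound 4 `CN(CCCn1cc[n+](C)c1/C=N/O)S(=O)(=O)C(F)(F)F` differs from compound 3 by methyl in place of hydrogen on a sulfonamide nitrogen. Within the data shown here, no measured step covers this change, so the expectation rests on compound 3 at -1.26 alone. Compound 4 is expected at -0.9, between -1.4 and -0.4. The estimated step of a number 0.36 log units higher from compound 3 to compound 4 (beyond the scatter) is a modest rise.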

Compound 4, distribution coefficient: -1.37
The estimate for compound 4 lay 0.47 log units above the measured number; measured number inside the range.
By their numbers in this assay, from the lowest: compound 2; then compounds 4 and 3 (each within the scatter of the next). At a limit, below all of these: compound 1.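

The change of methyl in place of hydrogen on a sulfonamide nitrogen gives no step beyond the scatter in this assay: a number 0.11 log units lower from compound 3 to compound 4 (within the scatter). Trifluoromethyl in place of methyl on a sulfonyl sulfur, by contrast, gives a number 1.26 log units higher from compound 2 to compound 4 (beyond the scatter). The step of a number at least 1.63 log units higher from compound 1 to compound 4 (beyond the scatter) starts from a limit and gives only a bound: the limit of < -3 in this assay, at which 1 of the 4 values shown sits.

On these data alone, whether hydrogen and methyl on this nitrogen also match when the sulfonyl sulfur carries methyl stays open. So does the outcome with ethyl on this nitrogen, or with a longer chain.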